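Chlorinated chromone with aminothiadiazole thioether: cytotoxicity expectation

The source may hold more compounds than are shown below. What is called first, only, known or untested is meant among the compounds shown, and "the series" means these compounds.

The series is built on a chromone core carrying a thioether-linked five-membered heteroaromatic ring. Compound 1 `Cc1nnc(SCc2cc(=O)c3cc(Cl)ccc3o2)o1` carries a methyl-substituted ring and a chloro group on the fused benzene; compound 2 `Nc1nnc(SCc2cc(=O)c3ccccc3o2)s1` carries an amino-substituted ring and no chloro group. In a functional assay on HEp-2 cells (Homo sapiens) for cytotoxicity, read by MTT assay, with a stated time of 72 h (on this read-out lower numbers stand for stronger inhibition and higher numbers for weaker inhibition), compound 1 reports only a limit, > 25000 nM. In this assay compound 2 also reports only a limit, > 25000 nM. Compound 2 therefore stands at the limit of > 25000 nM in this assay, at which 2 of the 2 values shown sit, with no numerical value to place it against.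

Compound 3 `Nc1nnc(SCc2cc(=O)c3cc(Cl)ccc3o2)s1` differs from compound 2 by chloro in place of hydrogen on an aromatic carbon. Going by the values given here, no step between two measured compounds is available to size this change. The same chloro group is present in compound 1, which in this assay reports only a limit, so nothing here points to a measurable gain. The expectation is that the step from compound 2 to compound 3 is a step that the limit leaves unreadable from compound 2 to compound 3, that is, none beyond the scatter. Compound 3 is estimated at 30000 nM, within 10000 nM to 100000 nM, most likely reported again as a limit.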

Compound 3, half-maximal inhibitory concentration: > 25000 nM
Compound 3: no number, only a limit (the forecaster's own chance of this, stated with the estimate: 85%); the middle value does not contradict the limit.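

In this assay compound 3 gives > 25000 nM, which is a limit. Going by these compounds alone, no step from compound 1 or compound 2 to compound 3 can be read, and the size of either change stays unknown: the limit of > 25000 nM in this assay, at which 3 of the 3 values shown sit. The compounds shown leave open whether any change on the shared core gives a measurable value in this assay.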